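A few compounds are considered here, and "the series" means these few. Any claim that something is new, unique, unknown or untested is made for them only; others in the source may bear on it.

Compounds measured in a functional assay on the whole organism (blood) with Rattus norvegicus as the target, with stated times of 24 h and 1 h, at a dose of 5 mg/kg by the intraperitoneal route; on this read-out higher numbers stand for a stronger effect at the one dose given and lower numbers for a weaker effect:
- compound 1, `COc1ccc(Cl)cc1C(=O)NCCC1CCN(S(=O)(=O)NC(=O)NC[C@H]2C[C@@H]3CC[C@@H]2O3)CC1`, gives 27%
- compound 2, `COc1ccc(Cl)cc1C(=O)NCCC1CCN(S(=O)(=O)NC(=O)NN2CCCCCC2)CC1`, gives 36%
- compound 3, `CC(=O)NCCC1CCN(S(=O)(=O)NC(=O)NC[C@@H]2C[C@@H]3C=C[C@@H]2C3)CC1`, gives 18%

Compound 3 has the lowest of the three numbers, but its value and that of compound 1 lie within the scatter of each other, so no order between the two can be claimed; only compound 2 stands beyond the scatter above compound 3. The unmeasured compound 4, `O=C(NC[C@@H]1C[C@@H]2C=C[C@@H]1C2)NS(=O)(=O)N1CCC(CCNC(=O)c2cc(Cl)cc3cccnc23)CC1`, is drawn from compound 3 by one change: 6-chloroquinolin-8-yl in place of methyl on a carbonyl carbon.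

For the measured compounds named here, only one measured step exists, a number 9 percentage points higher from compound 1 to compound 2 (within the scatter), and it concerns a group on an amide-type nitrogen at the other end of the shared core, not the carbonyl carbon altered here. Going by the values given here, no measured pair separates an acetyl from an aryl group on that carbonyl carbon, so the data give no direct guide. What can be said is that compound 1 and compound 2, which carry a larger group on that carbonyl than the methyl of compound 3, return the two higher numbers of the set. The expected step is therefore a number 10 percentage points higher from compound 3 to compound 4 (within the scatter), modest and uncertain. Compound 4 is expected to give 28%, within a range from 12% to 45%.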

Compound 4, a percentage reported as activity, at one dose (the size of the read-out at that dose, not a potency): 35%
The estimate for compound 4 lay 7 percentage points below the measured number; the measured number falls inside the stated range.
By their numbers in this assay, from the lowest: compounds 3, 1, 4 and 2 (each within the scatter of the next, the first and the last beyond it).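

In this assay the carbonyl carbon whose other neighbour is an amide-type nitrogen now proves to be a place where the read-out can respond: replacing methyl with 6-chloroquinolin-8-yl gives a number 17 percentage points higher from compound 3 to compound 4 (beyond the scatter), although the size of that step is modest. For the compounds shown here, the earlier compounds could not show this, as their only step concerned a group on an amide-type nitrogen at a different place and stayed within the scatter, whereas this pair isolates a change at the carbonyl carbon and yields the first single-place step beyond the scatter. Nothing measured here accounts for the rise, which comes with the move from a single carbon to a two-ring aromatic group containing nitrogen and chlorine.

The compounds shown leave open which part of the entering group matters, as they do not include plain quinolin-8-yl without the chlorine, a simple phenyl or a longer chain such as propyl on this carbonyl carbon. They also leave open whether the same exchange would give a comparable step with the group of compound 2 on the amide-type nitrogen.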